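Amide nitrogen substituent exchange in the shared core series

This account rests on a few compounds, and the source may have more. Where it says the series, first, only, none or still open, it means among the compounds named here.

Compound 1 `COc1cc(-c2cc(C(=O)O)c3ccccc3n2)ccc1OCC(=O)Nc1ccccc1F` gives 161000 nM in an ADME assay on HaCaT cells (Homo sapiens) for inhibition; on this read-out higher numbers stand for weaker inhibition and lower numbers for stronger inhibition. Compound 2 `COc1cc(-c2cc(C(=O)O)c3ccccc3n2)ccc1OCC(=O)Nc1ccccc1Cl` gives 210000 nM in this assay, and compound 3 `COc1cc(-c2cc(C(=O)O)c3ccccc3n2)ccc1OCC(=O)Nc1cccc(C(F)(F)F)c1` gives 160000 nM. All three numbers lie within the scatter of one another: a 1.3-fold higher number from compound 1 to compound 2 (0.12 log units; within the scatter), a 1.0-fold lower number from compound 1 to compound 3 (0.00 log units; within the scatter) and a 1.3-fold lower number from compound 2 to compound 3 (0.12 log units; within the scatter). On these numbers compound 1 stands with compound 3 nearest and compound 2 furthest, neither gap reaching beyond the scatter.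

Compound 4 `COc1cc(-c2cc(C(=O)O)c3ccccc3n2)ccc1OCC(=O)NCc1cccnc1` differs from compound 1 in one place: (pyridin-3-yl)methyl in place of 2-fluorophenyl on an amide-type nitrogen. The measured steps that bear on this are the two that also exchange the group on the amide-type nitrogen, a 1.0-fold lower number from compound 1 to compound 3 (0.00 log units; within the scatter) and a 1.3-fold lower number from compound 2 to compound 3 (0.12 log units; within the scatter), both within the scatter, together with a 1.3-fold higher number from compound 1 to compound 2 (0.12 log units; within the scatter). None of them introduces a (pyridin-3-yl)methyl group or a six-membered aromatic ring with 1 hetero atom, so the change in compound 4 goes beyond what the series has tested. With every measured step flat, no step beyond the scatter is expected for compound 4, and the expected step is a 1.0-fold lower number from compound 1 to compound 4 (0.00 log units; within the scatter). Compound 4 is estimated at 160000 nM, with a range from 70000 nM to 360000 nM.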

Compound 4, half-maximal inhibitory concentration: > 300000 nM
Compound 4 ended at the assay's limit; the forecaster's own chance of this, stated with the estimate: 25%; middle value at least 1.8-fold (0.27 log units) from the limit.
By their numbers in this assay, from the lowest: compounds 3, 1 and 2 (each within the scatter of the next). At a limit, above all of these: compound 4.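

this assay gives a limit for compound 4, not a number: the limit of > 300000 nM in this assay, at which 1 of the 4 values shown sits. The steps to it are an at least 1.8-fold higher number from compound 1 to compound 4 (0.27 log units; that floor lies within the scatter), an at least 1.8-fold higher number from compound 3 to compound 4 (0.27 log units; that floor lies within the scatter) and an at least 1.4-fold higher number from compound 2 to compound 4 (0.15 log units; that floor lies within the scatter); each is only a floor, and each floor lies within the scatter, so a real rise cannot be claimed from them. Even so, (pyridin-3-yl)methyl is the first group on this amide-type nitrogen to end at the limit, whereas the 2-fluorophenyl, 2-chlorophenyl and 3-(trifluoromethyl)phenyl compounds all give numbers within the scatter of one another.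

On these data alone, how far compound 4 lies past the limit stays open. This exchange alters both the ring and its attachment through a methyl link, so a plain benzyl group or a pyridin-3-yl group directly on the amide-type nitrogen would be needed to separate the two.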